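Replacing the piperazine side chain of compound 1 with bromo

The source may report more compounds than this note shows. Statements on the series, on what has been measured and on what is new or still open speak of the compounds shown alone.

- compound 1 `CN1CCN(CCCCCOc2c(Br)cc(Br)cc2Oc2ccc(Br)cc2Br)CC1` gives 49.1 ug/mL in a functional assay on U-937 cells (Homo sapiens) for cytotoxicity, read by MTT assay, with a stated time of 24 h; a lower number here means a stronger inhibitor, a higher number a weaker inhibitor
- compound 2 `COc1ccccc1N1CCN(CCCCCOc2c(Br)cc(Br)cc2Oc2ccc(Br)cc2Br)CC1` gives 37.5 ug/mL in this assay
- compound 3 `Cc1ccc(S(=O)(=O)n2nc(N3CCN(CCCCCOc4c(Br)cc(Br)cc4Oc4ccc(Br)cc4Br)CC3)c3cc([N+](=O)[O-])ccc32)cc1` gives 68.5 ug/mL in this assay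

Compound 1 stands within the scatter of both other compounds, so the three numbers give no ranking. Compound 4 `BrCCOc1c(Br)cc(Br)cc1Oc1ccc(Br)cc1Br` departs from compound 1 by one change (bromo in place of 3-(4-methylpiperazin-1-yl)propyl on a saturated chain carbon, two bonds along the chain from an oxygen on an aromatic ring), namely bromo in place of 3-(4-methylpiperazin-1-yl)propyl on a saturated chain carbon, two bonds along the chain from an oxygen on an aromatic ring. Among the compounds with values here, the only measured step, a 1.3-fold lower number from compound 1 to compound 2 (0.12 log units; within the scatter), alters a group on the ring amine nitrogen and keeps the ring. Compound 3 (68.5 ug/mL) keeps it too. Within the data shown here, no measured compound lacks the ring, so the evidence for this change is indirect and the direction stays open. In this assay the expected outcome is no shift beyond the scatter, an estimated 1.1-fold lower number from compound 1 to compound 4 (0.04 log units; within the scatter) with wide uncertainty. For compound 4 the estimated value is 45 ug/mL (expected range 15 ug/mL to 120 ug/mL).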

Compound 4, half-maximal inhibitory concentration: 32.5 ug/mL
For compound 4 the middle estimate is 1.4-fold (0.14 log units) above the measured one; measured number inside the range.
By their numbers in this assay, from the lowest: compounds 4, 2, 1 and 3 (each within the scatter of the next, the first and the last beyond it).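

With bromo in place of 3-(4-methylpiperazin-1-yl)propyl on a saturated chain carbon, two bonds along the chain from an oxygen on an aromatic ring, the step in this assay reads a 1.5-fold lower number from compound 1 to compound 4 (0.18 log units; within the scatter). Within the data shown here, compound 4 is the first compound without the piperazine ring, so neither this ring nor its amine nitrogens are required for a reading in the range of compound 1 in this series. No measured evidence on the cause of this result is available.

A single replacement cannot show whether bromo itself matters at this chain carbon, or whether any small group would give a comparable number. A hydroxyl, a carboxylic acid or a primary amine at the same carbon would separate these readings, and a longer chain ending in bromo would test the chain length.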